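Oxamide series: aryl versus cycloheptyl on the amide nitrogen

The source may report more compounds than this note shows. Statements on the series, on what has been measured and on what is new or still open speak of the compounds shown alone.

Compound 2 `Cc1nc(C(NC(=O)C(=O)NC2CCCCCC2)C2CCCCN2)sc1CCO` carries a cycloheptyl group on the amide-type nitrogen. In an ADME assay on TZM-b1 cells (Homo sapiens) for cytotoxicity, read by XTT assay, with a stated time of 3 days (a higher number here means that more compound is tolerated, a lower number that less compound is tolerated), compound 2 gives only a limit of the assay, > 88000 nM, so its number is not fixed. Compound 1 `Cc1nc(C(NC(=O)C(=O)Nc2ccc(Cl)c(F)c2)C2CCCCN2)sc1CCO` is its aryl counterpart; in this assay compound 1 gives 61000 nM. The step of an at least 1.4-fold higher number from compound 1 to compound 2 (0.15 log units; that floor lies within the scatter) is the only measured move in this series, and it rests on (the limit of > 88000 nM in this assay, at which 1 of the 2 values shown sits), so it carries little weight as a direction.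

Compound 3 `Cc1nc(C(NC(=O)C(=O)Nc2ccc(F)c(Cl)c2)C2CCCCN2)sc1CCO` is the unmeasured member. The change is 3-chloro-4-fluorophenyl in place of cycloheptyl on an amide-type nitrogen. This is close to the reverse of the measured step, since the group that enters differs from the aryl group of compound 1 only in the arrangement of its chlorine and fluorine. The measured step was small and sits at the limit, so in this assay no step beyond the scatter is firmly expected, though a return toward the number of compound 1 is the most plausible outcome. Compound 3 is therefore estimated at 60000 nM in this assay, with a range of 30000 nM to 100000 nM, meaning an expected step of an at least 1.4-fold lower number from compound 2 to compound 3 (0.16 log units; that floor lies within the scatter).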

Compound 3, half-maximal cytotoxic concentration: > 75800 nM
Compound 3 was reported as a limit; the forecaster's own chance of this, stated with the estimate: 35%; middle value at least 1.2-fold (0.10 log units) from the limit.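

Compound 3 gives > 75800 nM in this assay, which is a limit of the assay and not a number, so a halogenated aryl group on the amide-type nitrogen can also end at a limit, as the cycloheptyl group of compound 2 does. Exchanging 4-chloro-3-fluorophenyl for 3-chloro-4-fluorophenyl gives an at least 1.2-fold higher number from compound 1 to compound 3 (0.09 log units; that floor lies within the scatter), so the two aryl groups cannot be told apart here, and compound 1 alone no longer stands for how aryl groups behave at this position. The step between compound 2 and compound 3 cannot be read, because compound 3 also sits at a limit rather than at a number: the limit of > 75800 nM in this assay, at which 1 of the 3 values shown sits.

Going by these compounds, the true numbers for compound 2 and compound 3 stay open, and so does any ranking of cycloheptyl against the aryl groups. Also open, on these data alone, is how a phenyl group without halogens, a cyclohexyl group, a benzyl group or a phenyl group carrying a carboxylic acid on the same nitrogen would read in this assay.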